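Rearranging the amino ester substituent on the shared pyrimidine core

The source may hold more compounds than are shown below. What is called first, only, known or untested is meant among the compounds shown, and "the series" means these compounds.

Measured compounds:
- Compound 1 `COC(=O)CN(C)c1nc(NCc2ccccc2)ncc1[N+](=O)[O-]`: 85900 nM
- Compound 2 `COC(=O)CN(C)c1nc(Nc2cccc(OC)c2)ncc1[N+](=O)[O-]`: 93700 nM

Both compounds were tested in a functional assay on MCF7 cells (Homo sapiens) for antiproliferative activity, read by MTT assay, with a stated time of 48 h; on this read-out lower numbers stand for stronger inhibition and higher numbers for weaker inhibition. Compound 2 has the highest of the two numbers, but its nearest neighbour is within the scatter: a 1.1-fold higher number from compound 1 to compound 2 (0.04 log units; within the scatter). Among the compounds with values here, that single step concerns the group on the nitrogen bearing the 3-methoxyphenyl, not the position at issue here, so no measured step bears directly on the change to compound 3 `CCOC(=O)CNc1nc(Nc2cccc(OC)c2)ncc1[N+](=O)[O-]`. The change is ((ethoxycarbonyl)methyl)amino in place of ((methoxycarbonyl)methyl)(methyl)amino on an aromatic carbon. Within the data shown here, with no comparable step to draw on and no sign of strong sensitivity elsewhere on the core, compound 3 is expected to stay close to compound 2, with a 1.0-fold lower number from compound 2 to compound 3 (0.02 log units; within the scatter), that is, no step beyond the scatter. Compound 3 is therefore estimated at 90000 nM, in a range of 40000 nM to 200000 nM.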

Compound 3, half-maximal inhibitory concentration: 35800 nM
For compound 3 the middle estimate is 2.5-fold (0.40 log units) above the measured one; measured number outside the range, below it.
By their numbers in this assay, from the lowest: compound 3; then compounds 1 and 2 (each within the scatter of the next).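

The position on the aromatic carbon ortho to a nitro group responds in this assay, with a 2.6-fold lower number from compound 2 to compound 3 (0.42 log units; beyond the scatter) as the first step beyond the scatter among these compounds, whereas the earlier change at the other substituent stayed within it. The entering and leaving groups hold the same count of heavy atoms, so this shift comes from how those atoms are joined: the entering ((ethoxycarbonyl)methyl)amino group has an ethyl ester and a hydrogen on the amino nitrogen, and the leaving group has a methyl ester and a methyl on that nitrogen. No available evidence accounts for the step.

The ester and the amino nitrogen change together, so the compounds shown cannot assign the step to either one. From the compounds shown here alone, a ((methoxycarbonyl)methyl)amino group would separate the two, and a carboxylic acid or longer chain in place of the ester remains open.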